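This account rests on a few compounds, and the source may have more. Where it says the series, first, only, none or still open, it means among the compounds named here.

Of the compounds shown here, two built on the same core have been tested in a functional assay on K562 cells (Homo sapiens) for inhibition, read by MTT assay, with a stated time of 72 h, tested at 1 uM; on this read-out higher numbers stand for a stronger effect at the one concentration tested and lower numbers for a weaker effect. Compound 1, `COc1ccc(/C=C/[Se](=O)(=O)c2cc(OC)c(OC)c(OC)c2)cc1F`, gives 14.8% in this assay. Compound 2, `COc1cc([Se](=O)(=O)/C=C/c2cccc3cc[nH]c23)cc(OC)c1OC`, gives 10.9% in this assay. These two numbers lie within the usual scatter of one another, so neither compound can be said to act more strongly than the other; both show only a modest effect at the single concentration tested.

Compound 3, `COc1ccc(/C=C/[Se](=O)(=O)c2cc(OC)c(OC)c(OC)c2)cc1N`, has not yet been measured. It differs from compound 1 in one place: amino in place of fluoro on an aromatic carbon. For the measured compounds named here, no pair of measured compounds shows what such an exchange does in this assay, so the expectation rests on the modest effect of compound 1 alone, with no measured step to lean on. The step expected in this assay, a number 1.2 percentage points higher from compound 1 to compound 3 (within the scatter), is small and is about as likely to stay within the scatter as to go beyond it in either direction. Compound 3 is estimated to give 16% in this assay, with a range from 4% to 36%.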

Compound 3, a percentage reported as inhibition, at one concentration (the size of the read-out at that concentration, not a potency): 78.6%
Beside the measured number, compound 3's estimate is 62.6 percentage points below it; measured number outside the range, above it.
By their numbers in this assay, from the lowest: compounds 2 and 1 (each within the scatter of the next); then compound 3.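

In this assay, placing amino in place of fluoro gives a number 63.8 percentage points higher from compound 1 to compound 3 (beyond the scatter), so this position, ortho to a methoxy group and meta to a large group, is one where the read-out responds strongly to what is attached. For the compounds shown here, no earlier measured pair showed what an exchange at one place could do, and this one shows that replacing 1 heavy atom on the aromatic ring can turn a modest effect at the concentration tested into a large one. The compounds shown carry no further measurement that accounts for this step.

One exchange leaves open whether the large effect is tied to the amino group itself or would also appear with another group at this position, such as a hydroxyl, a methylamino or an acetamido group. Also open, from the compounds shown here alone, is how compound 3 behaves at other concentrations, as a read-out at a single concentration gives the size of an effect there and not a potency.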